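This account rests on a few compounds, and the source may have more. Where it says the series, first, only, none or still open, it means among the compounds named here.

Series notes. Compound 1 `COc1ccccc1-c1cc(C2CCN(C)C2)ccc1Cl` gives 12 nM in an assay on isolated protein for binding affinity to 5-hydroxytryptamine receptor 1B (Homo sapiens); a lower number here means a stronger inhibitor, a higher number a weaker inhibitor. Compound 2 `COc1ccccc1-c1cc(CN(C)C)ccc1Cl` gives 830 nM in this assay. Among the measured compounds shown here, the one step measured so far, a 69-fold higher number from compound 1 to compound 2 (1.84 log units; beyond the scatter), is the replacement of 1-methylpyrrolidin-3-yl by (dimethylamino)methyl on an aromatic carbon. For the measured compounds named here, on the two numbers in hand compound 2 stands highest, with compound 1 as its only neighbour. Compound 3 `CCCNCc1ccc(Cl)c(-c2ccccc2OC)c1` is not yet measured. It differs from compound 2 by propylamino in place of dimethylamino on a saturated chain carbon bound to an aromatic carbon; cut one bond further out, the change reads (dimethylamino)methyl to (propylamino)methyl. Going by the values given here, only the step from compound 1 to compound 2 is available for comparison, and it concerns the group that carries the nitrogen, not the substituents on the nitrogen; that step was large, but the present change is of a different kind. Among the compounds with values here, no measured step exchanges a dimethylamino for a propylamino, so the direction is open. The expectation is a step that stays close to the scatter, read as a 1.4-fold lower number from compound 2 to compound 3 (0.14 log units; within the scatter). Compound 3 is accordingly estimated at 600 nM, with a range from 200 nM to 2000 nM.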

Compound 3, inhibition constant: 640 nM
Beside the measured number, compound 3's estimate is 1.1-fold (0.03 log units) below it; low and high end bracket the measured number.
By their numbers in this assay, from the lowest: compound 1; then compounds 3 and 2 (each within the scatter of the next).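

On the saturated chain carbon bound to an aromatic carbon, propylamino in place of dimethylamino gives a 1.3-fold lower number from compound 2 to compound 3 (0.11 log units; within the scatter) in this assay, so this exchange, which brings a hydrogen-bond donor into the group by the counts of the two, gives no step beyond the scatter. (Propylamino)methyl in place of 1-methylpyrrolidin-3-yl gives a 53-fold higher number from compound 1 to compound 3 (1.73 log units; beyond the scatter), a large step like a 69-fold higher number from compound 1 to compound 2 (1.84 log units; beyond the scatter), so among the three compounds the number far lower than the others stays with the 1-methylpyrrolidin-3-yl group and is not recovered by this change on the nitrogen. No experimental evidence at hand bears on either step.

Going by these compounds, whether groups on the nitrogen generally make little difference remains open, since one pair cannot settle it; a primary amine, a butylamino group or a cyclic amine such as pyrrolidin-1-yl on the same chain carbon would extend the comparison. Also open, on these data alone, is what part of the 1-methylpyrrolidin-3-yl group carries the difference, which the same ring with hydrogen in place of the methyl on its nitrogen, or a piperidine ring, would begin to separate.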